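From 4-Methoxyphenyl to 3-Fluorophenyl on a Sulfur

A few compounds are considered here, and "the series" means these few. Any claim that something is new, unique, unknown or untested is made for them only; others in the source may bear on it.

Compound 1 `Nc1ccccc1NC(=O)/C=C/c1ccc(CSc2cccc(F)c2)cc1` gives 2.25%
Compound 2 `COc1ccc(SCc2ccc(C(=O)Nc3ccccc3N)cc2)cc1` gives 35%

In a functional assay on HeLa cells (Homo sapiens) for inhibition, read by CCK-8 assay, with a stated time of 72 h, tested at 2 uM (on this read-out higher numbers stand for more inhibition of growth at the one concentration tested and lower numbers for less inhibition of growth), compound 2 stands highest of the two measured compounds with 35% and lies beyond the scatter from its nearest neighbour (compound 1 with 2.25%). Compound 3 `Nc1ccccc1NC(=O)c1ccc(CSc2cccc(F)c2)cc1` has 3-fluorophenyl in place of 4-methoxyphenyl on a sulfur and has not yet been measured. For the measured compounds named here, no measured step covers this change. The expected move a number 5 percentage points lower from compound 2 to compound 3 (within the scatter) is slightly downward and stays within the scatter of this assay readings. The estimate for compound 3 is 30% with an expected range of 12% to 52% in this test.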

Compound 3, percent growth inhibition at one concentration: 22.5%
Estimate against measurement, compound 3: 7.5 percentage points above, within the range that was stated.
By their numbers in this assay, from the lowest: compound 1; then compound 3; then compound 2.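

In this assay, for the compounds shown here, the exchange of 4-methoxyphenyl for 3-fluorophenyl on a sulfur gives a number 12.5 percentage points lower from compound 2 to compound 3 (beyond the scatter) and is the only measured step at this position. It shows that the group on the sulfur changes growth inhibition on the shared core, although compound 3 keeps part of the inhibition seen with compound 2. Nothing measured here accounts for this step.

On these data alone, whether the step follows from the exchange of methoxy for fluorine or from the different ring position remains open. A 3-methoxyphenyl or 4-fluorophenyl group on the sulfur would separate the two.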